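From ethoxy to methoxy: notes on compound 4

This account rests on a few compounds, and the source may have more. Where it says the series, first, only, none or still open, it means among the compounds named here.

Values from a functional assay on thoracic aorta (Rattus norvegicus, strain Wistar), with a stated time of 15 min (a higher number here means that more compound is needed for the effect, a lower number that less compound is needed), follow:
- Compound 1 `COc1ccc(Br)cc1C(C)NC(=O)NS(=O)(=O)c1ccccc1`: > 300000 nM (a limit)
- Compound 2 `COc1ccc(Br)cc1C(C)NC(=O)N(C)S(=O)(=O)c1ccc(Cl)cc1`: 19100 nM
- Compound 3 `CCOc1ccc(Br)cc1C(C)NC(=O)NS(=O)(=O)c1ccc(Cl)cc1`: 171000 nM

The entry for compound 1 is a limit and not a number. Compound 3 (171000 nM) holds the higher of the two numeric values, and compound 2 lies lower by a gap beyond the scatter. Compound 4 `COc1ccc(Br)cc1C(C)NC(=O)NS(=O)(=O)c1ccc(Cl)cc1` differs from compound 3 by hydrogen in place of methyl on a saturated chain carbon bound to an oxygen on an aromatic ring, which is ethoxy to methoxy. For the measured compounds named here, no measured pair isolates this change. A small move toward a lower number is expected in this assay, with the estimated step of a 1.4-fold lower number from compound 3 to compound 4 (0.15 log units; within the scatter) staying within the scatter. Compound 4 is estimated at 120000 nM (expected range 40000 nM to 300000 nM).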

Compound 4, half-maximal effective concentration: 80900 nM
Estimate against measurement, compound 4: 1.5-fold (0.17 log units) above; the range from low to high includes it.
By their numbers in this assay, from the lowest: compound 2; then compound 4; then compound 3. At a limit, above all of these: compound 1.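

In this assay, for the compounds shown here, hydrogen in place of methyl on a saturated chain carbon bound to an oxygen on an aromatic ring gives a 2.1-fold lower number from compound 3 to compound 4 (0.33 log units; beyond the scatter), the first reading of ethoxy to methoxy. On the amide-type nitrogen, the same exchange gives a 4.2-fold higher number from compound 2 to compound 4 (0.63 log units; beyond the scatter), so this methyl and the oxygen chain can be read separately. Compound 1 stands at a limit, so chloro in place of hydrogen on an aromatic carbon gives only a bound, an at least 3.7-fold lower number from compound 1 to compound 4 (0.56 log units; beyond the scatter), and not a measured size: the limit of > 300000 nM in this assay, at which 1 of the 4 values shown sits.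

The compounds shown leave open how a propoxy chain or a free hydroxyl would read at this oxygen. Also open, from the compounds shown here alone, is whether ethoxy and the nitrogen methyl together would follow these two steps.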